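Amine tail trimming from compound 3 to compound 4

The compounds below may be only part of what the source reports. "The series", "measured", "known", "first", "only" and "open" are said of these compounds alone.

Measured compounds:
compound 1, `C#Cc1cccc(Nc2ncnc3ccc(NC(=O)Nc4ccc(CN5CCN(C)CC5)cc4)cc23)c1`, 2810 nM
compound 2, `CN1CCN(Cc2ccc(NC(=O)Nc3ccc4ncnc(Nc5cccc(C(=O)N6CCCC6)c5)c4c3)cc2)CC1`, > 10000 nM
compound 3, `O=C(Nc1ccc(CN2CCCCC2)cc1)Nc1ccc2ncnc(Nc3cccc(C(F)(F)F)c3)c2c1`, 1550 nM

In a functional assay on A-431 cells (Homo sapiens) for antiproliferative activity, read by MTT assay, with a stated time of 72 h (a lower number here means a stronger inhibitor, a higher number a weaker inhibitor), compound 1 gives 2810 nM and compound 3 gives 1550 nM; the two sit within the scatter of each other. In this assay compound 2 reaches only a limit, > 10000 nM, which is the limit of > 10000 nM in this assay, at which 1 of the 3 values shown sits. Among the measured compounds shown here, the one step between measured compounds, an at least 3.5-fold higher number from compound 1 to compound 2 (0.55 log units; beyond the scatter), changes a group on an aromatic carbon of the aniline side and not the amine tail.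

Compound 4, `CN(C)Cc1ccc(NC(=O)Nc2ccc3ncnc(Nc4cccc(C(F)(F)F)c4)c3c2)cc1`, is not yet measured. It differs from compound 3 by dimethylamino in place of piperidin-1-yl on a saturated chain carbon bound to an aromatic carbon. For the measured compounds named here, no measured step touches this position, so nothing shows how this tail affects the number. The open-chain amine and the ring amine are both tertiary, and the rest of the molecule is unchanged. The expected step of a 1.0-fold higher number from compound 3 to compound 4 (0.01 log units; within the scatter) therefore lies within the scatter. Compound 4 is estimated at 1600 nM, with a range from 600 nM to 4500 nM.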

Compound 4, half-maximal inhibitory concentration: 1030 nM
For compound 4 the middle estimate is 1.6-fold (0.19 log units) above the measured one, within the range that was stated.
By their numbers in this assay, from the lowest: compounds 4, 3 and 1 (each within the scatter of the next, the first and the last beyond it). At a limit, above all of these: compound 2.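

In this assay, the first step read at this position, a 1.5-fold lower number from compound 3 to compound 4 (0.18 log units; within the scatter), comes with dimethylamino in place of piperidin-1-yl on a saturated chain carbon bound to an aromatic carbon. The six-membered non-aromatic ring of the tail can therefore give way to an open-chain amine with fewer heavy atoms without the number moving beyond the scatter, at least with the rest of compound 3 held constant. No measured property in hand bears on this step.

Still open, going by these compounds, is whether a tail carrying a primary amine, a morpholine ring or a carboxylic acid at this place would stay within the scatter as well. Also open, on these data alone, is whether dimethylamino would behave the same way alongside the ethynyl group of compound 1.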